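The source may hold more compounds than are shown below. What is called first, only, known or untested is meant among the compounds shown, and "the series" means these compounds.

Three compounds share one core and differ only in the group hanging from the saturated chain carbon bound to the amine nitrogen in the outer ring. Compound 1 `CNC(=O)c1cnc(N2CCN(C3CCN(Cc4ccc(Cl)cc4)CC3)[C@@H](C)C2)c(Cl)c1` gives 32 nM in a functional assay for antagonist activity at C-X-C chemokine receptor type 3 (Homo sapiens); on this read-out lower numbers stand for stronger inhibition and higher numbers for weaker inhibition. Compound 2 `CNC(=O)c1cnc(N2CCN(C3CCN(Cc4ccc[nH]4)CC3)[C@@H](C)C2)c(Cl)c1` gives 8060 nM in this assay, and the step of a 250-fold higher number from compound 1 to compound 2 (2.40 log units; beyond the scatter) is the largest in the set. Compound 3 `CNC(=O)c1cnc(N2CCN(C3CCN(Cc4ccc(F)cc4Cl)CC3)[C@@H](C)C2)c(Cl)c1` gives 58 nM, the second highest of the three numbers; its nearest neighbour is compound 1, and a 1.8-fold higher number from compound 1 to compound 3 (0.26 log units; within the scatter), while a 140-fold lower number from compound 2 to compound 3 (2.14 log units; beyond the scatter).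

Compound 4 `CNC(=O)c1cnc(N2CCN(C3CCN(C(=O)c4ccc(Cl)cc4)CC3)[C@@H](C)C2)c(Cl)c1` has not been measured. The change is (4-chlorophenyl)carbonyl in place of 2-chloro-4-fluorobenzyl on an amine nitrogen in a ring. Both measured steps swap one ring for another while keeping the saturated chain carbon that links ring and nitrogen; none alters that linking carbon to a carbonyl. Among the compounds with values here, the steps therefore show only that a chlorinated benzene ring at this position has been tolerated, and nothing about the carbonyl that enters. Compound 4 is expected to be weaker in this assay, with a 10-fold higher number from compound 3 to compound 4 (1.01 log units; beyond the scatter) as the anticipated shift. Compound 4 is estimated at 600 nM, in a range from 60 nM to 6000 nM.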

Compound 4, half-maximal inhibitory concentration: 210 nM
Compound 4: the middle estimate sits 2.9-fold (0.46 log units) above what was measured; low and high end bracket the measured number.
By their numbers in this assay, from the lowest: compounds 1 and 3 (each within the scatter of the next); then compound 4; then compound 2.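

Within the data shown here, the first change to the linking carbon itself shows that this position does not depend on it entirely: in this assay, replacing 4-chlorobenzyl with (4-chlorophenyl)carbonyl leaves the same chlorinated ring in place and gives only a modest loss (a 6.6-fold higher number from compound 1 to compound 4 (0.82 log units; beyond the scatter)), and the loss against 2-chloro-4-fluorobenzyl is also modest (a 3.6-fold higher number from compound 3 to compound 4 (0.56 log units; beyond the scatter)). The carbonyl compound still lies far from the pyrrole compound (a 38-fold lower number from compound 2 to compound 4 (1.58 log units; beyond the scatter)), so a carbonyl-linked chlorinated benzene ring keeps much of the inhibition that the (1H-pyrrol-2-yl)methyl group lacks. Nothing available explains why the carbonyl costs this much.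

The compounds shown leave open how a sulfonyl group or a longer chain would fare on this ring nitrogen. They also leave open whether a carbonyl would cost the same with a 2-chloro-4-fluorophenyl or 1H-pyrrol-2-yl ring.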